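The source may hold more compounds than are shown below. What is called first, only, known or untested is meant among the compounds shown, and "the series" means these compounds.

Compound 1 `C[C@H]1C[C@H]1C(=O)N1CC2CNCC2C1`: 110%
Compound 2 `C[C@H]1C[C@@H]1C(=O)N1CC2CNCC2C1`: 26%
Compound 3 `O=C(C1CC1)[C@H]1C[C@H]2CNC[C@H]2C1`: 130%

In an assay on CHO cells for agonist activity at Neuronal acetylcholine receptor; alpha3/beta4 (Homo sapiens), read by FLIPR and calcium flux (a lower number here means a smaller maximal response, a higher number a larger maximal response), compound 3 holds the highest of the three numbers; compound 1 stands nearest, and compound 2 furthest. For the measured compounds named here, the only step measured between two compounds that differ in one place is a number 84 percentage points lower from compound 1 to compound 2 (beyond the scatter); it turns on a stereocentre drawn one way in one and the other way in the other (the fact that one of compounds 1 and 2 is drawn with a defined configuration and the other without, at the place where they differ), and so says nothing about an exchange of groups on the carbonyl carbon. Compound 4 `O=C(c1ccco1)[C@H]1C[C@H]2CNC[C@H]2C1` differs from compound 3 by furan-2-yl in place of cyclopropyl on a carbonyl carbon. Going by the values given here, no measured step covers such a change, so the writer expects compound 4 to stay near compound 3, with a number 20 percentage points lower from compound 3 to compound 4 (beyond the scatter) as the estimated step. Compound 4 is therefore estimated at 110%, between 60% and 145%.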

Compound 4, largest response reached (Emax), in percent of the reference or control that the assay uses: 40%
Estimate against measurement, compound 4: 70 percentage points above; measured number outside the range, below it.
By their numbers in this assay, from the lowest: compound 2; then compound 4; then compound 1; then compound 3.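

In this assay, the exchange on the carbonyl carbon gives a number 90 percentage points lower from compound 3 to compound 4 (beyond the scatter), so the maximal response depends strongly on the group at this place, not only on the stereocentre that separated the earlier pair. Furan-2-yl is thus far from interchangeable with cyclopropyl here, even though the shared core stays the same. Nothing measured here offers a reason for this drop. The compounds shown leave open whether the drop follows the aromatic ring or its ring oxygen. They also leave open how phenyl, thiophen-2-yl or an ethyl chain would read on the same carbonyl carbon.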